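Cytotoxicity of a cyanobenzyl triazole analogue

The source may report more compounds than this note shows. Statements on the series, on what has been measured and on what is new or still open speak of the compounds shown alone.

Compound 3 `Cc1cc(C)c(Oc2cc(Nc3ccc(C#N)cc3)ncc2C(=O)NCc2cn(CCCO)nn2)c(C)c1` gives 25200 nM in an ADME assay on MT4 cells (Homo sapiens) for cytotoxicity, read by MTT assay, with a stated time of 5 days (on this read-out higher numbers stand for lower toxicity in this test and lower numbers for higher toxicity in this test), the lowest of the three numbers: compound 1 `Cc1cc(C)c(Oc2cc(Nc3ccc(C#N)cc3)ncc2C(=O)NCc2cn(Cc3cccc(Cl)c3)nn2)c(C)c1` gives 187000 nM and compound 2 `Cc1cc(C)c(Oc2cc(Nc3ccc(C#N)cc3)ncc2C(=O)NCc2cn(CC(=O)N3CCOCC3)nn2)c(C)c1` gives 181000 nM. Compound 4 `Cc1cc(C)c(Oc2cc(Nc3ccc(C#N)cc3)ncc2C(=O)NCc2cn(Cc3cccc(C#N)c3)nn2)c(C)c1` differs from compound 3 by 3-cyanophenyl in place of 2-hydroxyethyl on a saturated chain carbon bound to an aromatic nitrogen. For the measured compounds named here, two measured steps bear on this change, both ending at compound 3: a 7.4-fold lower number from compound 1 to compound 3 (0.87 log units; beyond the scatter) and a 7.2-fold lower number from compound 2 to compound 3 (0.86 log units; beyond the scatter). Compound 1 carries a 3-chlorophenyl group at the very place where compound 4 carries the 3-cyanophenyl group, so the change to compound 4 essentially reverses the earlier step. Because a 7.4-fold lower number from compound 1 to compound 3 (0.87 log units; beyond the scatter) was modest but beyond the scatter, compound 4 is expected to show a comparable step the other way, a 6.7-fold higher number from compound 3 to compound 4 (0.83 log units; beyond the scatter). Compound 4 is therefore estimated at 170000 nM, within a range from 70000 nM to 320000 nM.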

Compound 4, half-maximal cytotoxic concentration: >= 129000 nM
Compound 4 ended at the assay's limit; the forecaster's own chance of this, stated with the estimate: 5%; the middle value is on the limit's open side.
By their numbers in this assay, from the lowest: compound 3; then compounds 2 and 1 (each within the scatter of the next).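

In this assay compound 4 gives >= 129000 nM, which is a limit of the assay and not a number. At this place, on a saturated chain carbon bound to an aromatic nitrogen, 3-cyanophenyl in place of 2-hydroxyethyl gives an at least 5.1-fold higher number from compound 3 to compound 4 (0.70 log units; beyond the scatter), so a second aromatic group besides the 3-chlorophenyl of compound 1 now lies beyond the scatter from compound 3. The steps from compound 1 and compound 2 to compound 4 cannot be read, because of this limit: the limit of >= 129000 nM in this assay, at which 1 of the 4 values shown sits.

On these data alone, whether cyano and chloro differ in this assay therefore remains open. As far as these compounds go, how an amine, a carboxylic acid or a longer chain would read at this place also remains open.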